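Amide replaces trifluoromethyl on a carboxylic acid isoxazole series

This account rests on a few compounds, and the source may have more. Where it says the series, first, only, none or still open, it means among the compounds named here.

Of the compounds shown here, two sharing a common core have been measured in an assay for inhibition of inositol hexakisphosphate kinase 3 (Homo sapiens), read by colorimetric assay, coupled enzyme assay and malachite green, with a stated time of 120 min, in the presence of a further agent that is not named here; a lower number here means a stronger inhibitor, a higher number a weaker inhibitor. Compound 1 `O=C(O)c1ccc2noc(-c3ccc(Oc4ccccc4)cc3)c2c1` gives 550 nM in this assay. Compound 2 `O=C(O)c1ccc2noc(-c3cccc(C(F)(F)F)c3)c2c1`, which carries a trifluoromethyl group instead of the phenoxy group, gives 4620 nM, the higher of the two numbers, and its gap to compound 1 lies beyond the usual scatter. Compound 3 `O=C(O)c1ccc2noc(-c3cccc(NC(=O)C4CC4)c3)c2c1` has not yet been measured. Relative to compound 2 it shows one change: (cyclopropylcarbonyl)amino in place of trifluoromethyl on an aromatic carbon, at the place described as on an aromatic carbon of a six-membered aromatic ring of carbon only, meta to a large group. Going by the values given here, no measured pair shows this kind of exchange, so no measured step guides the expectation directly. Compound 1 with its larger group gives the lower number, yet that group sits elsewhere, so only a modest step is expected. Compound 3 is estimated at 2000 nM, within 500 nM to 8000 nM, which would mean an expected step of a 2.3-fold lower number from compound 2 to compound 3 (0.36 log units; beyond the scatter).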

Compound 3, half-maximal inhibitory concentration: 2810 nM
Estimate against measurement, compound 3: 1.4-fold (0.15 log units) below; low and high end bracket the measured number.
By their numbers in this assay, from the lowest: compound 1; then compounds 3 and 2 (each within the scatter of the next).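

In this assay, going by these compounds alone, the exchange at this aromatic carbon, meta to a large group, is the first measured change at this place, and it reads as a 1.6-fold lower number from compound 2 to compound 3 (0.22 log units; within the scatter). The two groups therefore cannot be told apart in this assay, even though (cyclopropylcarbonyl)amino brings a hydrogen-bond donor, a hydrogen-bond acceptor and a three-membered ring that trifluoromethyl lacks. Nothing measured here offers an explanation for this result.

Going by these compounds, whether a simple amine, a carboxylic acid or a longer chain on this same aromatic carbon would move the number beyond the scatter remains open. On these data alone, it is also open whether the amide needs its cyclopropyl ring, which a comparison with a methyl group in its place could address.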